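A Halogen Exchanged on the Outer Ring of Compound 3

The source may hold more compounds than are shown below. What is called first, only, known or untested is meant among the compounds shown, and "the series" means these compounds.

Of the compounds shown here, three have so far been measured in a functional assay on KB cells (Homo sapiens) for inhibition, read by sulforhodamine B assay, with a stated time of 48 h, tested at 10 uM; on this read-out higher numbers stand for more inhibition of growth at the one concentration tested and lower numbers for less inhibition of growth. Compound 1 `COc1ccccc1/C=N/NC(=O)c1ccc(-c2ccc(F)cc2F)o1` gives 59.5%, compound 2 `COc1ccccc1C(=O)N/N=C/c1ccc(-c2ccc(F)cc2F)o1` gives 10.1%, and compound 3 `O=C(N/N=C/c1ccc(Cl)cc1)c1ccc(-c2ccccc2F)o1` gives 11.3%. Compound 3 thus stands second highest of the three numbers. Its value and that of compound 2 lie within the scatter of each other, so nothing can be said about which of the two is the stronger, while compound 1 lies far above both, well beyond the scatter.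

Compound 4 `O=C(N/N=C/c1cccc(Br)c1)c1ccc(-c2ccccc2F)o1` has not yet been measured. It differs from compound 3 in a single place: 3-bromophenyl in place of 4-chlorophenyl on a carbon with a double bond to nitrogen. Both groups are a single six-membered aromatic ring of carbon carrying one halogen, with no hydrogen-bond donors or acceptors and no charge, so the change is a modest one.

For the measured compounds named here, no pair of measured compounds differs in a way that resembles this exchange, so there is no measured step to lean on; the expectation rests on compound 3 alone. The expected step of a number 3.7 percentage points higher from compound 3 to compound 4 (within the scatter) is therefore small, with no direction expected beyond the scatter. Compound 4 is estimated at 15%, within a range from 3% to 35%.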

Compound 4, percent growth inhibition at one concentration: 26.5%
Estimate against measurement, compound 4: 11.5 percentage points below, within the range that was stated.
By their numbers in this assay, from the lowest: compounds 2 and 3 (each within the scatter of the next); then compound 4; then compound 1.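

In this assay, exchanging 4-chlorophenyl for 3-bromophenyl on a carbon with a double bond to nitrogen gives a number 15.2 percentage points higher from compound 3 to compound 4 (beyond the scatter), so the read-out at this position responds even to a modest change: both groups are a single six-membered aromatic ring of carbon carrying one halogen, with no hydrogen-bond donors or acceptors and no net charge. For the compounds shown here, the earlier compounds offered no pair differing in one place, so this is the first step in the set that can be tied to a single location, although the halogen and its place on the ring differ together, and this one step cannot divide the effect between them. Nothing measured here explains the step.

From the compounds shown here alone, whether the halogen or its place on the ring matters more stays open, and 3-chlorophenyl and 4-bromophenyl at this same position would separate the two. Going by these compounds, it is also open how this position would respond to a ring carrying something other than a halogen, such as an amine or a carboxylic acid.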